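Fluoro for Methyl on the Pyridine of Compound 2

This account rests on a few compounds, and the source may have more. Where it says the series, first, only, none or still open, it means among the compounds named here.

Measured so far:
Compound 1, `NCCCCCOC[C@H]1O[C@@H](OCCc2c[nH]c3ccccc23)[C@H](OCc2ccccc2)[C@@H](OCc2ccccc2)[C@@H]1OCc1cnccn1`, gives 260 nM in an assay on isolated protein for binding affinity to somatostatin receptor type 4 (Homo sapiens), read by radioligand binding; on this read-out higher numbers stand for weaker inhibition and lower numbers for stronger inhibition.
Compound 2, `Cc1ccc(CO[C@H]2[C@H](OCc3ccccc3)[C@@H](OCc3ccccc3)[C@H](OCCc3c[nH]c4ccccc34)O[C@@H]2COCCCCCN)cn1`, gives 1260 nM in this assay.

Among the compounds with values here, compound 2 stands at the higher of the two numbers; the only measured step, a 4.8-fold higher number from compound 1 to compound 2 (0.69 log units; beyond the scatter), separates it from compound 1. Compound 3, `NCCCCCOC[C@H]1O[C@@H](OCCc2c[nH]c3ccccc23)[C@H](OCc2ccccc2)[C@@H](OCc2ccccc2)[C@@H]1OCc1ccc(F)nc1`, differs from compound 2 in one place: fluoro in place of methyl on an aromatic carbon. Within the data shown here, no measured step bears directly on this exchange. Among the measured compounds shown here, the single step of a 4.8-fold higher number from compound 1 to compound 2 (0.69 log units; beyond the scatter) changes the whole six-membered aromatic ring and its substituent at once, so it does not tell how trading methyl for fluoro on the ring of compound 2 will read in this assay. With nothing comparable to lean on, the number for compound 3 is not expected to move far from that of compound 2. Compound 3 is therefore expected to show a step of a 1.3-fold lower number from compound 2 to compound 3 (0.10 log units; within the scatter), which may well lie within the scatter. Compound 3 is estimated at 1000 nM in this assay, within a range of 300 nM to 3500 nM.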

Compound 3, inhibition constant in the somatostatin receptor type 4 assay: 680 nM
Estimate against measurement, compound 3: 1.5-fold (0.17 log units) above, within the range that was stated.
By their numbers in the somatostatin receptor type 4 assay, from the lowest: compound 1; then compounds 3 and 2 (each within the scatter of the next).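

In the somatostatin receptor type 4 assay, fluoro in place of methyl on the aromatic carbon next to the ring nitrogen gives a 1.9-fold lower number from compound 2 to compound 3 (0.27 log units; within the scatter), so this exchange has no readable effect on the binding number, something the earlier step could not show because it replaced the whole ring and its substituent at once. The 6-fluoropyridin-3-yl group still does not match pyrazin-2-yl, as the somatostatin receptor type 4 assay shows a 2.6-fold higher number from compound 1 to compound 3 (0.42 log units; beyond the scatter), and this agrees in direction with a 4.8-fold higher number from compound 1 to compound 2 (0.69 log units; beyond the scatter), so both pyridine compounds read on the weaker side of compound 1. In a physicochemical assay for acid dissociation, compound 2 gives 6.1 and compound 3 gives -0.4 across this exchange. While the number in the somatostatin receptor type 4 assay stays within the scatter, the same exchange moves the reading in the physicochemical assay a long way, so for this pair binding does not follow how readily the proton is given up: the measured acid dissociation constant of compound 2, 6.1, and of compound 3, -0.4, a number 6.50 log units lower (beyond the scatter)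

The compounds shown leave open how a trifluoromethyl or methoxy group on this same aromatic carbon would read in the somatostatin receptor type 4 assay. They also leave open whether a substituent on the pyrazin-2-yl ring of compound 1 would be tolerated as readily as the methyl and fluoro groups are on the pyridine.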